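Trading trifluoromethyl for cyano in a small cytotoxic series

A few compounds are considered here, and "the series" means these few. Any claim that something is new, unique, unknown or untested is made for them only; others in the source may bear on it.

In a functional assay on HepG2 cells (Homo sapiens) for cytotoxicity, read by MTT assay, with a stated time of 24 h (a lower number here means a stronger inhibitor, a higher number a weaker inhibitor), compound 1 `O=C1/C(=C/c2cccnc2)CN(S(=O)(=O)c2ccccc2)C/C1=C\c1ccccc1F` gives 8210 nM, compound 2 `Cc1ccc(S(=O)(=O)N2C/C(=C\c3cccnc3)C(=O)/C(=C/c3ccccc3F)C2)cc1` gives 4200 nM and compound 3 `O=C1/C(=C/c2cccnc2)CN(S(=O)(=O)c2ccc(C(F)(F)F)cc2)C/C1=C\c1ccccc1F` gives 2400 nM. Two steps show where the last of these stands. There is a 3.4-fold lower number from compound 1 to compound 3 (0.53 log units; beyond the scatter), a modest but real gap, and there is a 1.8-fold lower number from compound 2 to compound 3 (0.24 log units; within the scatter), which cannot be told apart from repeat-measurement noise.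

Compound 4 `N#Cc1ccc(S(=O)(=O)N2C/C(=C\c3cccnc3)C(=O)/C(=C/c3ccccc3F)C2)cc1` changes one place of compound 3: cyano in place of trifluoromethyl on an aromatic carbon. This puts cyano in place of trifluoromethyl on an aromatic carbon, para to a large group. Within the data shown here, no measured compound carries cyano, so the nearest guides are the earlier changes at this same carbon. Replacing hydrogen gave a 2.0-fold lower number from compound 1 to compound 2 (0.29 log units; within the scatter) as well as the larger step above, while exchanging one group for another gave only a 1.8-fold lower number from compound 2 to compound 3 (0.24 log units; within the scatter). A second exchange of groups is therefore expected to stay within the scatter, with no clear direction. The expected step is a 1.3-fold higher number from compound 3 to compound 4 (0.10 log units; within the scatter). For compound 4 the estimated value is 3000 nM, with an expected range from 1400 nM to 6500 nM.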

Compound 4, half-maximal inhibitory concentration: 6600 nM
For compound 4 the middle estimate is 2.2-fold (0.34 log units) below the measured one; measured number above the stated range.
By their numbers in this assay, from the lowest: compounds 3, 2, 4 and 1 (each within the scatter of the next, the first and the last beyond it).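

Among the exchanges of one group for another at this aromatic carbon, only this one gives a step beyond the scatter in this assay (a 2.8-fold higher number from compound 3 to compound 4 (0.44 log units; beyond the scatter)), so the choice between trifluoromethyl and cyano matters here. Cyano cannot be told apart from methyl (a 1.6-fold higher number from compound 2 to compound 4 (0.20 log units; within the scatter)) or from hydrogen (a 1.2-fold lower number from compound 1 to compound 4 (0.09 log units; within the scatter)). Of the three groups tested at this carbon, only trifluoromethyl is clearly separated from hydrogen (a 3.4-fold lower number from compound 1 to compound 3 (0.53 log units; beyond the scatter)), so placing just any group here does not give a clear step.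

The compounds shown offer no measurement that accounts for the gap between trifluoromethyl and cyano. From the compounds shown here alone, it remains open whether an amine, a carboxylic acid or a methoxy group at this carbon would fall nearer to trifluoromethyl or to cyano, and whether the same gap would appear with other changes to the shared core.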